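The compounds below may be only part of what the source reports. "The series", "measured", "known", "first", "only" and "open" are said of these compounds alone.

Among the measured compounds shown here, compound 3 `CN1CCc2nc(C#Cc3ccccn3)ccc2C1=O` stands at the top of the three numbers so far: in an assay on HEK293 cells for displacement of a labelled ligand from metabotropic glutamate receptor 5 (Homo sapiens), with a stated time of 2 h (on this read-out higher numbers stand for weaker inhibition and lower numbers for stronger inhibition), compound 3 gives 6240 nM. Its nearest neighbour is compound 2 `CN1CCc2nc(C#Cc3ccc(Cl)cc3)ccc2C1=O`, which in this assay gives 6150 nM, and the two are placed together as a 1.0-fold higher number from compound 2 to compound 3 (0.01 log units; within the scatter). The furthest is compound 1 `CN1CCc2nc(C#Cc3cccc(Cl)c3)ccc2C1=O`, which in this assay gives 250 nM; the gap runs as a 25-fold higher number from compound 1 to compound 3 (1.40 log units; beyond the scatter), and the companion step a 25-fold higher number from compound 1 to compound 2 (1.39 log units; beyond the scatter) is of the same size.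

Compound 4 `CC(C)N1CCc2nc(C#Cc3ccccn3)ccc2C1=O` differs from compound 3 in a single place: isopropyl in place of methyl on an amide-type nitrogen in a ring. For the measured compounds named here, every measured step so far exchanges the aryl group on the triple-bonded carbon, while the amide-type nitrogen in the ring carries a methyl in compound 1, compound 2 and compound 3 alike. Going by the values given here, no measured step therefore bears on the change from methyl to isopropyl at that nitrogen, and the large steps from compound 1 give no guide to it. With nothing to point in either direction, the step is expected to be none beyond the scatter, a 1.0-fold lower number from compound 3 to compound 4 (0.02 log units; within the scatter), carrying a wide range. Compound 4 is accordingly estimated to give 6000 nM in this assay, within 1800 nM to 20000 nM.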

Compound 4, inhibition constant: 2740 nM
Compound 4: the middle estimate sits 2.2-fold (0.34 log units) above what was measured, and the stated range covers the measured number.
By their numbers in this assay, from the lowest: compound 1; then compound 4; then compounds 2 and 3 (each within the scatter of the next).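

Among the compounds shown here, the first measured step at the amide-type nitrogen in the ring shows that this position is not silent in this assay: with pyridin-2-yl held on the triple-bonded carbon, isopropyl in place of methyl gives a 2.3-fold lower number from compound 3 to compound 4 (0.36 log units; beyond the scatter) and so moves the number towards stronger inhibition. The step is modest, but it lies beyond the scatter, and it shows that the larger of these two alkyl groups is accepted at this nitrogen without any loss in this assay. The compounds shown offer no measured basis for explaining why the number moves in this direction.

For the compounds shown here, since this change is seen only with pyridin-2-yl on the triple-bonded carbon, it remains open whether isopropyl would have a similar effect with 3-chlorophenyl or 4-chlorophenyl there. Going by these compounds, it is also open whether the trend would continue, stop or reverse with a hydrogen on this nitrogen, with a cyclopropyl or benzyl group, or with a longer chain ending in an amine.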